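The source may report more compounds than this note shows. Statements on the series, on what has been measured and on what is new or still open speak of the compounds shown alone.

Compounds measured so far:

- Compound 1, `N#C/C(=C\c1ccc(Cl)cc1)C(=O)c1ccc[nH]1`, gives 52000 nM in a functional assay on A-431 cells (Homo sapiens) for inhibition, read by MTT assay, with a stated time of 72 h; on this read-out lower numbers stand for stronger inhibition of growth and higher numbers for weaker inhibition of growth.
- Compound 2, `N#C/C(=C\c1ccc([N+](=O)[O-])cc1)C(=O)c1c[nH]c2ccccc12`, gives 46000 nM in this assay.
- Compound 3, `COc1ccc(CNC(=O)/C(C#N)=C/c2ccco2)cc1`, gives 16000 nM in this assay.

Of the three numbers, compound 3 stands lowest. Its nearest neighbour is compound 2, whose number is higher by a margin that goes beyond the usual scatter of repeated measurements, and compound 1 lies further off still, also beyond the scatter. On the read-out of this assay, compound 3 is therefore the strongest inhibitor of growth among the compounds measured. Among the measured compounds shown here, the three compounds differ in more than one place, so no single step between them can be isolated.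

Compound 4, `COc1ccc(CNC(=O)/C(C#N)=C/c2ccc(C)cc2)cc1`, has not yet been measured. It differs from compound 3 in one place: 4-methylphenyl in place of furan-2-yl on a double-bonded chain carbon bound to a double-bonded chain carbon. The rest of the molecule, including the amide part, is kept.

For the measured compounds named here, no measured pair shows what this change does in this assay. The expectation for compound 4 is therefore cautious: the step of a 1.3-fold higher number from compound 3 to compound 4 (0.10 log units; within the scatter) is estimated to stay close to or within the scatter, with no firm direction. Compound 4 is expected to give about 20000 nM, with a range from 6000 nM to 60000 nM.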

Compound 4, concentration for 50% growth inhibition: 26000 nM
Beside the measured number, compound 4's estimate is 1.3-fold (0.11 log units) below it, and the stated range covers the measured number.
By their numbers in this assay, from the lowest: compounds 3, 4, 2 and 1 (each within the scatter of the next, the first and the last beyond it).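

In this assay, among the compounds shown here, the first pair that differs in one place gives a 1.6-fold higher number from compound 3 to compound 4 (0.21 log units; within the scatter) when 4-methylphenyl takes the place of furan-2-yl on a double-bonded chain carbon bound to a double-bonded chain carbon, with the amide part kept. At this position, then, a five-membered aromatic ring with one hetero atom and a six-membered aromatic ring of carbon only cannot be told apart on this read-out, even though the hydrogen-bond acceptor counted in furan-2-yl is absent from 4-methylphenyl. No measurement at hand offers an explanation for this result.

The compounds shown leave open whether a group such as a dimethylamino group or a carboxylic acid, set on the aromatic ring in place of the methyl of compound 4, would give a step beyond the scatter. They also leave open whether the exchange of furan-2-yl for 4-methylphenyl would stay within the scatter with a longer chain on the amide nitrogen in place of the group carried by compound 3 and compound 4.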